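Shortening a Sulfur Chain in a Cytotoxicity Series

A few compounds are considered here, and "the series" means these few. Any claim that something is new, unique, unknown or untested is made for them only; others in the source may bear on it.

Of the compounds shown here, three have been tested in a functional assay on HT-29 cells (Homo sapiens) for cytotoxicity, read by MTT assay, with a stated time of 72 h; a higher number here means that more compound is tolerated, a lower number that less compound is tolerated. The first is compound 1 `CCCCC[Se]c1nc([Se]CCCCC)c2ccccc2n1`. In this assay compound 1 gives > 100000 nM, which is a limit of the assay and not a number. The second is compound 3 `CSc1nc(NCc2ccccc2)c2cccnc2n1`. In this assay compound 3 gives > 100000 nM, again a limit rather than a measured number. The third, and the starting point of the step followed here, is compound 2 `CCCCCSc1nc(NCc2ccc([Se]C)cc2)c2ccccc2n1`. In this assay compound 2 gives > 100000 nM, also a limit and not a number. Going by the values given here, compound 2 therefore stands exactly where the other two stand: all three sit at the limit of > 100000 nM in this assay, at which 3 of the 3 values shown sit, and no compound in the set has a measured number to compare against.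

The next compound, compound 4 `CSc1nc(NCc2ccc([Se]C)cc2)c2ccccc2n1`, has not yet been measured. It differs from compound 2 in one place: hydrogen in place of butyl on a saturated chain carbon bound to a sulfur. Among the compounds with values here, no measured pair in this set shows the effect of such a change, so the expectation rests only on where compound 2 itself sits. The step in this assay from compound 2 to compound 4 is expected to be a number no higher from compound 2 to compound 4 (the limit leaves the size open), none beyond the scatter. Compound 4 is accordingly expected at 100000 nM, in a range from 40000 nM to 300000 nM, most likely again reported only as a limit.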

Compound 4, concentration lethal to 50% of the cells: > 100000 nM
Compound 4: no number, only a limit; the forecaster's own chance of this, stated with the estimate: 80%; the middle value lies on the limit itself.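

Compound 2 and compound 4 both carry only a limit and not a number in this assay, so no step can be read between them: the limit of > 100000 nM in this assay, at which 4 of the 4 values shown sit. The compounds shown leave open whether going from pentylsulfanyl to methylsulfanyl changes cytotoxicity at all, and what the lethal concentration of any of them would be.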